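The compounds below may be only part of what the source reports. "The series", "measured", "known", "first", "only" and "open" are said of these compounds alone.

Of the compounds shown here, three that share a core have been measured so far. In an ADME assay on Caco-2 cells (Homo sapiens) for permeability, in the apical to basolateral direction, with a stated time of 90 min, tested at 10 uM (on this read-out lower numbers stand for lower permeability and higher numbers for higher permeability), compound 1 (`O=C(NC[C@@H]1[C@H]2CN(C(=O)CCc3cc(Cl)cc(Cl)c3)C[C@@H]12)c1ccc2[nH]c(=O)oc2c1`) gives 18 10^-6 cm/s, the lowest of the three numbers. Compound 2 (`O=C(NC[C@@H]1[C@H]2CN(C(=O)N3CCc4c(Cl)cc(Cl)cc4C3)C[C@@H]12)c1ccc2[nH]c(=O)oc2c1`) gives 47 10^-6 cm/s, and compound 3 (`N#Cc1cc(COC(=O)N2C[C@@H]3[C@@H](CNC(=O)c4ccc5[nH]c(=O)oc5c4)[C@@H]3C2)cc(OC(F)(F)F)c1`) gives 44 10^-6 cm/s. The gaps from compound 1 to each of the other two lie beyond the scatter, so it stands clearly at the bottom of this small set.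

The next compound to be read is compound 4 (`Cc1ccc(COC(=O)N2C[C@@H]3[C@@H](CNC(=O)c4ccc5[nH]c(=O)oc5c4)[C@@H]3C2)nc1`). Its structural change from compound 1 is a group of 9 heavy atoms (7 carbon, 1 nitrogen, 1 oxygen; one six-membered aromatic ring with 1 hetero atom) in place of a group of 10 heavy atoms (8 carbon, 2 chlorine; one six-membered aromatic ring of carbon only), on a carbonyl carbon. The 2-(3,5-dichlorophenyl)ethyl group therefore leaves, and a group with an aromatic ring holding one hetero atom enters on the same carbonyl carbon.

Among the compounds with values here, no step between measured compounds isolates this kind of change, so the expectation rests on indirect evidence. The group on that carbonyl carbon also holds an oxygen in compound 3, which gives 44 10^-6 cm/s in this assay, while the dichlorophenyl starting point, compound 1, gives 18 10^-6 cm/s. A modest rise that stays within the scatter is expected, and the estimated change is a 1.7-fold higher number from compound 1 to compound 4 (0.22 log units; within the scatter). For compound 4 the estimated permeability is 30 10^-6 cm/s, with an expected range from 14 10^-6 cm/s to 58 10^-6 cm/s.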

Compound 4, apparent permeability in the Caco-2 assay: 1 10^-6 cm/s
Beside the measured number, compound 4's estimate is 30-fold (1.48 log units) above it; measured number outside the range, below it.
By their numbers in the Caco-2 assay, from the lowest: compound 4; then compound 1; then compounds 3 and 2 (each within the scatter of the next).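

Within the data shown here, exchanging the 2-(3,5-dichlorophenyl)ethyl group on this carbonyl carbon gives the first step in the set that changes one place only, and the two read-outs move in opposite directions: in the Caco-2 assay the step is an 18-fold lower number from compound 1 to compound 4 (1.26 log units; beyond the scatter), while in a physicochemical assay for solubility, with a stated time of 24 h, at pH 2.2 (on this read-out higher numbers stand for higher solubility and lower numbers for lower solubility), it is an at least 92-fold higher number from compound 1 to compound 4 (1.96 log units; beyond the scatter). In the physicochemical assay compound 1 gives < 1 ug/mL, which is a limit of the assay. In the physicochemical assay compound 4 gives > 92 ug/mL, which is also a limit of the assay.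

This one step changes the ring, the chlorine atoms and the atoms that link the ring to the carbonyl carbon all at once, so the compounds shown cannot assign either shift to any one of these parts. They also leave open how the two read-outs would respond to a benzyloxy group without chlorine on the same carbonyl carbon, or to an amine placed on the aromatic ring of the entering group.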